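Swapping bromo for fluoro on the shared core of compound 1

A few compounds are considered here, and "the series" means these few. Any claim that something is new, unique, unknown or untested is made for them only; others in the source may bear on it.

Compound 1 `COc1cc(C(=O)NC2CCN(C)CC2)ccc1Nc1ncc(Br)c(NC2CCCC2)n1` gives the lowest number of the two measured compounds in a functional assay on HepG2 cells (Homo sapiens) for cytotoxicity, read by MTT assay, with a stated time of 48 h (on this read-out higher numbers stand for weaker inhibition and lower numbers for stronger inhibition), at 4900 nM. Compound 2 `CN1CCN(c2ccc(Nc3ncc(F)c(NC4CCCC4)n3)cc2)CC1` gives 25000 nM in this assay, a higher number that lies beyond the scatter. Compound 3 `COc1cc(C(=O)NC2CCN(C)CC2)ccc1Nc1ncc(F)c(NC2CCCC2)n1` has not yet been measured; it differs from compound 1 by fluoro in place of bromo on an aromatic carbon. Within the data shown here, no measured pair isolates this change, so its effect is unknown. He expects a modest step toward a higher number, a 1.6-fold higher number from compound 1 to compound 3 (0.21 log units; within the scatter), possibly still within the scatter. For compound 3 he estimates 8000 nM in this assay, within a range from 3000 nM to 25000 nM.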

Compound 3, half-maximal inhibitory concentration: 4500 nM
The estimate for compound 3 lay 1.8-fold (0.25 log units) above the measured number; the range from low to high includes it.
By their numbers in this assay, from the lowest: compounds 3 and 1 (each within the scatter of the next); then compound 2.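

In this assay, among these compounds, the change of bromo to fluoro is isolated here for the first time and gives a 1.1-fold lower number from compound 1 to compound 3 (0.04 log units; within the scatter), a step within the scatter. On this aromatic carbon, ortho to a cyclopentylamino group, the read-out therefore does not separate the two halogens on this core. Nothing measured on these compounds offers an explanation for this.

On these data alone, whether chloro, methyl, nitrile or an amine on the same carbon would also stay within the scatter remains open. So does whether the swap would give the same result with a longer chain in place of the cyclopentylamino group.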